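The source may report more compounds than this note shows. Statements on the series, on what has been measured and on what is new or still open speak of the compounds shown alone.

Of the compounds shown here, three sharing one core have been measured in a functional assay on HL-60 cells (Homo sapiens) for antiproliferative activity, with a stated time of 72 h; on this read-out higher numbers stand for weaker inhibition and lower numbers for stronger inhibition. Compound 1 `OC[C@H]1O[C@@H](n2cnc3c(NCc4ccccc4Cl)ncnc32)[C@H](O)[C@@H]1O` gives 1600 nM, compound 2 `OC[C@H]1O[C@@H](n2cnc3c(NCc4ccc(Br)cc4)ncnc32)[C@H](O)[C@@H]1O` gives 47400 nM, and compound 3 `OC[C@H]1O[C@@H](n2cnc3c(NCc4ccc(F)cc4F)ncnc32)[C@H](O)[C@@H]1O` gives 3400 nM. Compound 3 therefore holds the middle place of the three, with the second highest number, close to compound 1 and far from compound 2.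

Compound 4 `Cc1cccc(CNc2ncnc3c2ncn3[C@@H]2O[C@H](CO)[C@@H](O)[C@H]2O)c1O`, not yet measured, differs from compound 3 in one place: 2-hydroxy-3-methylphenyl in place of 2,4-difluorophenyl on a saturated chain carbon bound to a nitrogen on an aromatic ring. All three measured steps were made at this same place. The account records a 2.1-fold higher number from compound 1 to compound 3 (0.33 log units; beyond the scatter), a modest step, while a 30-fold higher number from compound 1 to compound 2 (1.47 log units; beyond the scatter) and a 14-fold lower number from compound 2 to compound 3 (1.14 log units; beyond the scatter) were both large, and both of those involve the 4-bromophenyl group. The entering group shares a substituent numbered 2 with 2-chlorophenyl and 2,4-difluorophenyl, which 4-bromophenyl lacks, so the modest step is taken as the closer guide. Among the measured compounds shown here, no measured compound carries a hydroxy or methyl group, however, and the large steps show how far this place can move the number.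

No step beyond the scatter is therefore expected in this assay, and no firm direction can be given. The expected change is a 1.1-fold lower number from compound 3 to compound 4 (0.05 log units; within the scatter). For compound 4 the estimated value is 3000 nM, with an expected range from 700 nM to 15000 nM.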

Compound 4, half-maximal inhibitory concentration: 15000 nM
Beside the measured number, compound 4's estimate is 5.0-fold (0.70 log units) below it, within the range that was stated.
By their numbers in this assay, from the lowest: compound 1; then compound 3; then compound 4; then compound 2.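

In this assay, among the compounds shown here, 2-hydroxy-3-methylphenyl, the one group at this place without a halogen, does not stay with 2-chlorophenyl and 2,4-difluorophenyl, as the two steps show: a 4.4-fold higher number from compound 3 to compound 4 (0.64 log units; beyond the scatter) and a 9.4-fold higher number from compound 1 to compound 4 (0.97 log units; beyond the scatter). The name of a group with a substituent numbered 2 is thus no sure sign of a low number here, and compound 4 goes against the grouping that compounds 1 and 3 suggested. Yet the number also stays clear of the top of the series, with a 3.2-fold lower number from compound 2 to compound 4 (0.50 log units; beyond the scatter), so the halogen-bearing compounds now lie on both sides of compound 4 and the presence of a halogen alone does not sort this series; nothing shown here accounts for these differences.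

On these data alone, what remains open is which part of the entering group goes with the higher number, the hydroxy or the methyl, and a 2-hydroxyphenyl or a 3-methylphenyl group at this place would separate the two. A 2-methoxyphenyl or a 2-aminophenyl group would further show whether the number follows the hydroxy group itself or extends to other oxygen or nitrogen substituents.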